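This account rests on a few compounds, and the source may have more. Where it says the series, first, only, none or still open, it means among the compounds named here.

Compound 1 `COc1ccc(C(O)CCN2CC=C(Cc3ccccc3)CC2)cc1` inhibits an assay on CHO cells for inhibition of sodium-dependent dopamine transporter (Homo sapiens), read by scintillation counting, with a stated time of 10 min, tested at 10 uM (on this read-out higher numbers stand for more inhibition at the one concentration tested (going by the name of the read-out) and lower numbers for less inhibition), with a reading of 57%. Its two companions differ in what sits at the end of the chain: compound 2 `OC(CCN1CCC(O)(Cc2ccccc2)CC1)c1csc2ccccc12` gives 64% and compound 3 `O=[N+]([O-])c1ccc(C(O)CCN2CC=C(Cc3ccccc3)CC2)cc1` gives 55%, so the number for compound 1 sits among both within the usual scatter. Going by the values given here, the single clean step, swapping nitro for methoxy on the aromatic ring, moved the reading by a number 2 percentage points lower from compound 1 to compound 3 (within the scatter). Compound 4 `OC(CCN1CC=C(Cc2ccccc2)CC1)c1ccc(F)cc1F` changes the same ring: 2,4-difluorophenyl in place of 4-methoxyphenyl on a saturated chain carbon bound to an oxygen on a saturated carbon and a saturated chain carbon. Because a number 2 percentage points lower from compound 1 to compound 3 (within the scatter) shows that replacing the group on this ring barely shifted the reading, no step beyond the scatter is expected, and compound 4 is estimated at 55%, ranging from 40% to 70%, meaning a change of a number 2 percentage points lower from compound 1 to compound 4 (within the scatter).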

Compound 4, a percentage reported as inhibition, at one concentration (the size of the read-out at that concentration, not a potency): 66%
Beside the measured number, compound 4's estimate is 11 percentage points below it; the measured number falls inside the stated range.
By their numbers in this assay, from the lowest: compounds 3, 1, 2 and 4 (each within the scatter of the next, the first and the last beyond it).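

In this assay, 2,4-difluorophenyl in place of 4-methoxyphenyl gives a number 9 percentage points higher from compound 1 to compound 4 (within the scatter). This is a second replacement on this ring to stay within the scatter, and it shows that the oxygen of the methoxy group can go, along with its hydrogen-bond acceptor, without a step beyond it. Nothing available explains this result. As far as these compounds go, whether an amine or a carboxylic acid on this ring would move the reading beyond the scatter remains open. So does the effect of a longer chain.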